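The source may hold more compounds than are shown below. What is called first, only, known or untested is meant among the compounds shown, and "the series" means these compounds.

Compound 1 `CC(C)C(c1nnc[nH]1)c1ccc(-c2ccc3cccc(F)c3c2)[nH]c1=O`: in an ADME assay on microsomes from liver (Mus musculus) for metabolic stability (a lower number here means that the compound disappears faster, a higher number that the compound lasts longer), compound 1 gives 0.213 h.
Compound 2 `CC(C)C(Cc1ncc[nH]1)c1ccc(-c2ccc3cccc(F)c3c2)[nH]c1=O`: in this assay compound 2 reaches a limit of the assay, < 0.0667 h, not a number (the limit of < 0.0667 h in this assay, at which 1 of the 3 values shown sits).
Compound 3 `CCn1ncc2c(F)cc(-c3ccc(C(CC)(CC)c4nnc(C)[nH]4)c(=O)[nH]3)cc21`: in this assay compound 3 is also given only as a limit of the assay, > 3 h (the limit of > 3 h in this assay, at which 1 of the 3 values shown sits).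

Compound 3 thus stands at the upper edge of what this assay reports, with one other value among the three being a limit as well. Compound 4 `CCn1ncc2c(F)cc(-c3ccc(C(CC)(CC)c4ncn(C)n4)c(=O)[nH]3)cc21` differs from compound 3 in one place: 1-methyl-1H-1,2,4-triazol-3-yl in place of 5-methyl-4H-1,2,4-triazol-3-yl on a saturated chain carbon bound to an aromatic carbon and two saturated chain carbons. Within the data shown here, the single measured step, an at least 3.1-fold lower number from compound 1 to compound 2 (0.50 log units; beyond the scatter), concerns a different change, the replacement of a triazolyl ring by an imidazolylmethyl group, so it does not bear directly on the change from compound 3 to compound 4. Among the measured compounds shown here, no measured step on this shared core touches the exchange of one methyltriazolyl ring for another. Compound 4 is therefore expected to stay close to compound 3, with a step of an at least 1.2-fold lower number from compound 3 to compound 4 (0.07 log units; that floor lies within the scatter) that is not expected to go beyond the scatter. The estimate for compound 4 in this assay is 2.5 h, within 0.8 h to 6 h.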

Compound 4, half-life: > 3 h
Compound 4: a limit, no number; the forecaster's own chance of this, stated with the estimate: 55%; middle value at least 1.2-fold (0.07 log units) from the limit.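

Like compound 3, compound 4 is given in this assay only as a limit, not a number, so no step from compound 3 to compound 4 can be read: the limit of > 3 h in this assay, at which 2 of the 4 values shown sit.

The compounds shown leave open whether 1-methyl-1H-1,2,4-triazol-3-yl in place of 5-methyl-4H-1,2,4-triazol-3-yl changes the half-life at all.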